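The source may hold more compounds than are shown below. What is called first, only, known or untested is meant among the compounds shown, and "the series" means these compounds.

Measured so far:
Compound 1, `COc1cccc(N2C(=O)/C(=C/c3cc(C)n(-c4cccc(-c5nnn[nH]5)c4)c3C)SC2=S)c1`, in an ADME assay on MT2 cells (Homo sapiens) for cytotoxicity, read by XTT assay, with a stated time of 4 days (on this read-out lower numbers stand for higher toxicity in this test and higher numbers for lower toxicity in this test), gives 40600 nM.
Compound 2, `Cc1cc(/C=C2\SC(=S)N(c3ccc(C(F)(F)F)cc3)C2=O)c(C)n1-c1cccc(-c2nnn[nH]2)c1`, in this assay gives 27100 nM.

Compound 2 has the lower of the two numbers, but the distance to it, a 1.5-fold lower number from compound 1 to compound 2 (0.18 log units; within the scatter), is within the scatter, so the two compounds cannot be told apart on this read-out. Compound 3, `Cc1cc(/C=C2\SC(=S)N(Cc3ccccc3)C2=O)c(C)n1-c1cccc(-c2nnn[nH]2)c1`, is the next compound in the same series; it differs from compound 2 by benzyl in place of 4-(trifluoromethyl)phenyl on an amide-type nitrogen in a ring. Among the compounds with values here, the only measured step that touches the same position, the amide-type nitrogen in the ring, is a 1.5-fold lower number from compound 1 to compound 2 (0.18 log units; within the scatter), and that change of the group on that nitrogen left the number within the scatter. Within the data shown here, with only this one step to go on, the expectation for compound 3 is a step no larger than the scatter, a 1.1-fold higher number from compound 2 to compound 3 (0.04 log units; within the scatter). Compound 3 is therefore estimated at 30000 nM in this assay, with a range from 12000 nM to 75000 nM.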

Compound 3, half-maximal cytotoxic concentration: 150000 nM
Compound 3: middle estimate off by 5.0-fold (0.70 log units), on the low side; measured number outside the range, above it.
By their numbers in this assay, from the lowest: compounds 2 and 1 (each within the scatter of the next); then compound 3.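

Putting benzyl on the amide-type nitrogen in the ring gives a 5.5-fold higher number from compound 2 to compound 3 (0.74 log units; beyond the scatter) in this assay and a 3.7-fold higher number from compound 1 to compound 3 (0.57 log units; beyond the scatter) as well, both beyond the scatter. Higher numbers here stand for lower toxicity in this test, so compound 3 is the least toxic of the three. The group on this nitrogen can therefore shift the read-out, which the earlier pair of substituted phenyl groups did not show, and no measurement at hand explains the shift.

The compounds shown cannot tell whether the rise goes with benzyl as such or simply with losing the methoxy and trifluoromethyl substituents. A plain phenyl, a longer chain such as phenethyl, or a benzyl carrying an amine on its ring would help separate these readings.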